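The source may report more compounds than this note shows. Statements on the series, on what has been measured and on what is new or still open speak of the compounds shown alone.

For the measured compounds named here, compound 3 `CCCCCCCS(=O)(=O)/C=C/c1ccc(O)c(O)c1` gives 7100 nM in a functional assay, read by fluorescence and spectrophotometry, with a stated time of 1 h (a higher number here means that more compound is needed for the effect, a lower number that less compound is needed), and stands second highest of the three numbers so far. Its closest neighbour is compound 1 `CCCCCCCCCCS(=O)(=O)/C=C/c1ccc(O)c(O)c1` at 6800 nM, the step being a 1.0-fold higher number from compound 1 to compound 3 (0.02 log units; within the scatter). Compound 2 `O=S(=O)(/C=C/c1ccc(O)c(O)c1)CC1CCC1` gives 8800 nM, and a 1.2-fold lower number from compound 2 to compound 3 (0.09 log units; within the scatter), so all three values sit within the scatter of one another.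

Compound 4 `O=S(=O)(/C=C/c1ccc(O)c(O)c1)CC1CCCO1` differs from compound 3 by oxolan-2-yl in place of hexyl on a saturated chain carbon bound to a sulfonyl sulfur. The step that bears most directly is the one from cyclobutyl to hexyl at the same place, a 1.2-fold lower number from compound 2 to compound 3 (0.09 log units; within the scatter), which stayed within the scatter, as did the chain shortening a 1.0-fold higher number from compound 1 to compound 3 (0.02 log units; within the scatter). Swapping the chain for a small saturated ring at this position is therefore expected to give no step beyond the scatter in this assay, a 1.1-fold higher number from compound 3 to compound 4 (0.05 log units; within the scatter). Compound 4 is estimated at 8000 nM, with a range from 4000 nM to 16000 nM.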

Compound 4, half-maximal effective concentration: 10500 nM
Estimate against measurement, compound 4: 1.3-fold (0.12 log units) below, within the range that was stated.
By their numbers in this assay, from the lowest: compounds 1, 3, 2 and 4 (each within the scatter of the next).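

For the compounds shown here, with oxolan-2-yl, a ring holding one hydrogen-bond acceptor now stands on the saturated chain carbon bound to a sulfonyl sulfur, where the earlier compounds carried only carbon groups. In this assay, it stays within the scatter when it replaces hexyl (a 1.5-fold higher number from compound 3 to compound 4 (0.17 log units; within the scatter)) and when it replaces cyclobutyl (a 1.2-fold higher number from compound 2 to compound 4 (0.08 log units; within the scatter)). No supporting measurement bears on these steps.

Going by these compounds alone, every step at this place so far lies within the scatter. From the compounds shown here alone, whether an amine or a carboxylic acid here would move the number beyond it remains open.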